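The compounds below may be only part of what the source reports. "The series", "measured", "known", "first", "only" and "open" are said of these compounds alone.

Working notes on the series. Two compounds have numbers in an assay on isolated protein for inhibition of Hematopoietic prostaglandin D synthase (Homo sapiens), read by ELISA; a higher number here means a weaker inhibitor, a lower number a stronger inhibitor. Compound 1 `O=C(NCc1ccccc1)c1ccc(-c2ccccc2)nc1` in this assay gives 1230 nM. Compound 2 `O=C(NCc1ccccc1)c1cnc(-c2ccccn2)nc1` in this assay gives 35.7 nM, the lowest of the two numbers; compound 1 is the nearest neighbour, and its number is higher by a margin beyond the scatter. Compound 1 and compound 2 differ in more than one place, so no single step between them is shown; their two values only bracket the range covered so far.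

Compound 3 `O=C(NCc1ccccc1)c1cnc(-c2ccccc2)nc1` has not been measured in this assay. It differs from compound 2 by phenyl in place of pyridin-2-yl on an aromatic carbon. Compound 1 carries the same phenyl group on a different core and sits well above compound 2, so the change is expected to move the number upward rather than leave it flat, though how much of the gap between compound 1 and compound 2 belongs to this one change cannot be read from two points. The step from compound 2 to compound 3 is expected to be a 6.2-fold higher number from compound 2 to compound 3 (0.79 log units; beyond the scatter), beyond the scatter. Compound 3 is therefore estimated at 220 nM, within a range of 60 nM to 800 nM.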

Compound 3, half-maximal inhibitory concentration: 23.9 nM
Compound 3: the middle estimate sits 9.2-fold (0.96 log units) above what was measured; the whole stated range lies above it.
By their numbers in this assay, from the lowest: compounds 3 and 2 (each within the scatter of the next); then compound 1.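

In this assay, phenyl in place of pyridin-2-yl on the aromatic carbon between two ring nitrogen atoms gives a 1.5-fold lower number from compound 2 to compound 3 (0.17 log units; within the scatter) and so, on this core, the two groups cannot be told apart, even though the hydrogen-bond acceptor counted on pyridin-2-yl is gone in phenyl. Compound 3 gives 23.9 nM and compound 1 gives 1230 nM with the same phenyl group on a different core, so the wide gap between compound 1 and compound 2 does not lie with the swap of pyridin-2-yl for phenyl, and the core difference between compound 1 and compound 3 now stands out as the place to look. No measurement at hand bears on why phenyl and pyridin-2-yl sit level here.

Going by these compounds, whether the level values hold for other groups at this position remains open, for instance for a saturated amine, a carboxylic acid or a longer chain in place of phenyl. On these data alone, all three compounds also share the same amide end, so the effect of any change there, such as a methoxy group on its ring, stays unknown.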